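Working notes: the step from compound 3 to compound 4

A few compounds are considered here, and "the series" means these few. Any claim that something is new, unique, unknown or untested is made for them only; others in the source may bear on it.

Measured so far in an ADME assay on NHDF cells (Homo sapiens) for cytotoxicity, read by MTT assay, with a stated time of 72 h; a lower number here means a stronger inhibitor, a higher number a weaker inhibitor
- compound 1 `COc1ccc(/C=C2\CCC/C(=C\c3ccccc3Cl)C2=O)cc1OC` at 21600 nM
- compound 2 `COc1ccc(/C=C2\CCC/C(=C\c3ccc(Br)cc3)C2=O)cc1OC` at 13100 nM
- compound 3 `COc1ccccc1/C=C1\CCC/C(=C\c2ccc(OC)c(OC)c2)C1=O` at 18100 nM

Compound 3 sits at 18100 nM in this assay and cannot be separated from the other two compounds, as all three lie within the scatter of one another. The next structure, compound 4 `COc1ccc(/C=C2\CCC/C(=C\c3cccc(Cl)c3Cl)C2=O)cc1OC`, has 2,3-dichlorophenyl in place of 2-methoxyphenyl on a double-bonded chain carbon bound to a double-bonded ring carbon. The nearest measured change is methoxy in place of chloro on an aromatic carbon (a 1.2-fold lower number from compound 1 to compound 3 (0.08 log units; within the scatter)). The two steps that exchange the whole aryl group at this place are also small (a 1.6-fold lower number from compound 1 to compound 2 (0.22 log units; within the scatter)) and (a 1.4-fold higher number from compound 2 to compound 3 (0.14 log units; within the scatter)). None of these steps leaves the scatter, so no step beyond the scatter is expected here, in either direction. The estimated step is a 1.1-fold lower number from compound 3 to compound 4 (0.05 log units; within the scatter) and would stay within that scatter. Compound 4 is estimated at 16000 nM (expected range 8000 nM to 30000 nM).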

Compound 4, half-maximal inhibitory concentration: 18500 nM
Compound 4: the middle estimate sits 1.2-fold (0.06 log units) below what was measured, and the stated range covers the measured number.
By their numbers in this assay, from the lowest: compounds 2, 3, 4 and 1 (each within the scatter of the next).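

In this assay, 2,3-dichlorophenyl on a double-bonded chain carbon bound to a double-bonded ring carbon cannot be told apart from 2-methoxyphenyl, a 1.0-fold higher number from compound 3 to compound 4 (0.01 log units; within the scatter), or from 4-bromophenyl, a 1.4-fold higher number from compound 2 to compound 4 (0.15 log units; within the scatter). The series now also holds a single-atom change on this aryl group, chloro in place of hydrogen on an aromatic carbon, and this too stays flat, a 1.2-fold lower number from compound 1 to compound 4 (0.07 log units; within the scatter). No measurement at hand bears on why these aryl exchanges read alike.

As far as these compounds go, whether an aryl group carrying an amine or a carboxylic acid at this place would give a step beyond the scatter remains open. Also open, from the compounds shown here alone, is whether the flat reading would hold for a change on the other aryl group or in the shared core.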